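This account rests on a few compounds, and the source may have more. Where it says the series, first, only, none or still open, it means among the compounds named here.

Measured compounds:
- compound 1, `Cc1nn(-c2ncnc3nc[nH]c23)c2c1C(OCc1ccccc1F)CC(=O)N2`, 4 nM
- compound 2, `Cc1nn(-c2ncnc3nc[nH]c23)c2c1C(NC(=O)Cc1cccs1)CC(=O)N2`, 3 nM
- compound 3, `Cc1nn(-c2ncnc3nc[nH]c23)c2c1C(OC(=O)c1ccc(F)cc1)CC(=O)N2`, 4 nM

These three share one core and differ only in the group on one saturated ring carbon. In a functional assay on HEK293 cells for agonist activity at G-protein coupled receptor 39 (Homo sapiens), read by scintillation proximity assay and inositol phosphate accumulation, with a stated time of 75 min, in the presence of a further agent that is not named here (on this read-out lower numbers stand for an effect already at smaller amounts and higher numbers for an effect only at larger amounts of compound), compound 3 gives 4 nM, level with compound 1 at the digits shown, and its gap to compound 2 is within the scatter. Compound 4, `Cc1nn(-c2ncnc3nc[nH]c23)c2c1C(OCc1ccccc1Cl)CC(=O)N2`, has not yet been measured. It differs from compound 3 by 2-chlorobenzyl in place of (4-fluorophenyl)carbonyl on an oxygen on a saturated carbon.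

Three measured steps speak to this change. The step of no change at the digits printed from compound 1 to compound 3 (within the scatter) exchanges a benzyl-type group on the oxygen for an aryl carbonyl and leaves the number unchanged. The steps of a 1.3-fold lower number from compound 1 to compound 2 (0.12 log units; within the scatter) and a 1.3-fold higher number from compound 2 to compound 3 (0.12 log units; within the scatter) swap the whole group on the ring carbon and also stay within the scatter. Every variation seen so far at this position has left this assay unmoved, and compound 4 keeps the (benzyl)oxy arrangement of compound 1. The expected step of no change at the digits printed from compound 3 to compound 4 (within the scatter) is therefore none beyond the scatter, so compound 4 is estimated at 4 nM, within the range 1.5 nM to 12 nM.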

Compound 4, half-maximal effective concentration: 2 nM
The estimate for compound 4 lay 2.0-fold (0.30 log units) above the measured number; the range from low to high includes it.
By their numbers in this assay, from the lowest: compounds 4, 2, 1 and 3 (each within the scatter of the next).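

In this assay, within the data shown here, chloro in place of fluoro on an aromatic carbon gives a 2.0-fold lower number from compound 1 to compound 4 (0.30 log units; within the scatter), the first change here that touches only the halogen, and it stays within the scatter. The larger swaps agree: 2-chlorobenzyl in place of (4-fluorophenyl)carbonyl on the oxygen gives a 2.0-fold lower number from compound 3 to compound 4 (0.30 log units; within the scatter), and (2-chlorobenzyl)oxy in place of (((thiophen-2-yl)methyl)carbonyl)amino gives a 1.5-fold lower number from compound 2 to compound 4 (0.18 log units; within the scatter), so all four compounds remain indistinguishable in this assay, whichever of these groups sits on the saturated ring carbon. No measurement is available that offers a reason for this sameness.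

From the compounds shown here alone, all four groups at this position carry an aromatic ring, so it stays open whether the number would hold with a plain amine, a carboxylic acid or a longer saturated chain there. A measured step beyond the scatter at this position would be needed to show which parts of these groups matter.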